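This account rests on a few compounds, and the source may have more. Where it says the series, first, only, none or still open, it means among the compounds named here.

In a functional assay on MOLT-3 cells (Homo sapiens) for antiproliferative activity (a higher number here means a weaker inhibitor, a lower number a stronger inhibitor), two compounds have been measured so far:

Compound 1, `CSc1nc2c([nH]1)C(=O)C=CC2=O`, gives 1.32 uM.
Compound 2, `CSc1nc2c([nH]1)C(=O)C(Br)=C(Br)C2=O`, gives 12 uM.

Of these two numbers, compound 2 stands at the higher one, which here means the weaker inhibitor. Among the measured compounds shown here, compound 1, the only other measured compound, gives the lower number, and the gap between them is beyond the usual scatter of this assay. The shared core of both compounds is the same; compound 2 differs from compound 1 only in carrying two bromo groups on the six-membered non-aromatic ring.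

The next compound, compound 3, `CSc1nc2c([nH]1)C(=O)C=C(Br)C2=O`, is not yet measured. It is reached from compound 2 by one change: hydrogen in place of bromo on a double-bonded ring carbon. Compound 3 thus keeps one of the two bromo groups of compound 2 and drops the other.

No pair of measured compounds differing in a single place is available, so the size of this step cannot be read from a shown step. What the two values show is that the compound without bromo gives the lower number and the compound with two bromo groups gives the higher one. Compound 3, with a single bromo group, is therefore expected to fall between them, and the step from compound 2 to compound 3 is expected to be a 3.0-fold lower number from compound 2 to compound 3 (0.48 log units; beyond the scatter), a drop beyond the scatter. For compound 3 the estimate in this assay is 4 uM, with a range from 1.5 uM to 10 uM.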

Compound 3, concentration for 50% inhibition: 32.1 uM
Beside the measured number, compound 3's estimate is 8.0-fold (0.90 log units) below it, and the stated range ends below it.
By their numbers in this assay, from the lowest: compound 1; then compound 2; then compound 3.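

In this assay, putting hydrogen in place of the bromo on this double-bonded ring carbon gives a 2.7-fold higher number from compound 2 to compound 3 (0.43 log units; beyond the scatter) and so yields a weaker inhibitor, which means that this bromo goes with the lower number when the neighbouring ring carbon also bears a bromo group. A single bromo on the core of compound 1 does the opposite, with a 24-fold higher number from compound 1 to compound 3 (1.39 log units; beyond the scatter) as its step, so adding a bromo to compound 1 raises the number while adding a second bromo to compound 3 lowers it. The effect of a bromo here therefore depends on what the neighbouring ring carbon carries, and nothing in the data given explains this reversal.

These three compounds leave open whether a lone bromo on the other double-bonded ring carbon would give a similar number to compound 3. They also leave open how a chloro group, a methyl group or an amine would behave on these carbons, alone or in pairs, and whether the same reversal would appear with any of them.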